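The source may report more compounds than this note shows. Statements on the series, on what has been measured and on what is new or still open speak of the compounds shown alone.

Compound 1 `CCCCCCCCCCCCCCCCCCNC(=O)[C@@H]1CSC(c2cc(OC)c(OC)c(OC)c2)N1`: 2400 nM
Compound 2 `CCCCCCCCCCCCCCCCCCNC(=O)[C@H]1NC(c2cc(OC)c(OC)c(OC)c2)SC1(C)C`: > 20000 nM, a limit

In a functional assay on TSU-Pr1 cells (Homo sapiens) for antiproliferative activity, read by sulforhodamine B assay (on this read-out lower numbers stand for stronger inhibition and higher numbers for weaker inhibition), compound 1 gives 2400 nM. Compound 2 in this assay stands at the limit of > 20000 nM in this assay, at which 1 of the 2 values shown sits, which is a limit of the assay and not a number. Compound 3 `CCCCCCCCCCCCCCCCCCNC(=O)[C@H]1NC(c2ccc(N(C)C)cc2)SC1(C)C` carries 4-(dimethylamino)phenyl in place of 3,4,5-trimethoxyphenyl on a saturated ring carbon. Among the measured compounds shown here, with compound 2 at a limit, no measured step informs the change. The expectation is for no step beyond the scatter, a step that the limit leaves unreadable from compound 2 to compound 3, with a further limit the most likely outcome. Compound 3 is therefore expected near 25000 nM, in the range 8000 nM to 80000 nM.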

Compound 3, half-maximal inhibitory concentration: > 20000 nM
Compound 3 gave a limit, no number; the forecaster's own chance of this, stated with the estimate: 70%; the middle value lies beyond the limit too.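

In this assay, among the compounds shown here, compound 2 and compound 3 both stand at a limit and not at a number, so no step between them can be read. The compounds shown leave open whether 4-(dimethylamino)phenyl in place of 3,4,5-trimethoxyphenyl changes the activity at all.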